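The compounds below may be only part of what the source reports. "The series", "measured", "known", "first", "only" and "open" are said of these compounds alone.

Of the compounds shown here, two have so far been measured in a physicochemical assay for solubility, in phosphate buffer, measured as kinetic solubility, at pH 7.4; a lower number here means a less soluble compound, a higher number a more soluble compound. Compound 1 `Cc1ccccc1-c1nc(CN2CCC(C(=O)NCCCN3[C@H](C)CCC[C@@H]3C)CC2)c(C)o1` is recorded only at a limit of the assay, > 69 ug/mL. That reading is the limit of > 69 ug/mL in this assay, at which 1 of the 2 values shown sits. Compound 2 `Cc1cccc(F)c1-c1nc(CN2CCC(C(=O)NCCCN3C[C@H](C)C[C@H](C)C3)CC2)c(C)o1` likewise reaches a limit of the assay rather than a number, > 72 ug/mL. Compound 2 therefore stands at the limit of > 72 ug/mL in this assay, at which 1 of the 2 values shown sits, and neither of the two readings can be ordered against the other.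

The account now follows the step from compound 2 to compound 3 `Cc1cc(C)cc(-c2nc(CN3CCC(C(=O)NCCCN4C[C@H](C)C[C@H](C)C4)CC3)c(C)o2)c1`. The change is 3,5-dimethylphenyl in place of 2-fluoro-6-methylphenyl on an aromatic carbon. Among the measured compounds shown here, no step between measured compounds is available, so the size of this change has to be judged from the two limits alone.

Given that compound 2 already sits at a limit with > 72 ug/mL, the step from compound 2 to compound 3 is expected to be none beyond the scatter, and compound 3 is expected to reach a limit again rather than a number. Compound 3 is estimated at 70 ug/mL, within a range from 25 ug/mL to 160 ug/mL. The step this estimate means is an at least 1.0-fold lower number from compound 2 to compound 3 (0.01 log units; that floor lies within the scatter).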

Compound 3, solubility: > 71 ug/mL
Compound 3: only a limit was reported (the forecaster's own chance of this, stated with the estimate: 60%); middle value at least 1.0-fold (0.00 log units) away from the limit.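

Compound 3 is recorded only at a limit in this assay, > 71 ug/mL. Among the compounds shown here, compound 2 also stands at a limit, so no step from compound 2 to compound 3 can be read. The compounds shown leave open how far compound 2 and compound 3 each lie past their limits, and whether 3,5-dimethylphenyl in place of 2-fluoro-6-methylphenyl changes the solubility at all.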